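A few compounds are considered here, and "the series" means these few. Any claim that something is new, unique, unknown or untested is made for them only; others in the source may bear on it.

Measured so far in an ADME assay on MT4 cells (Homo sapiens) for cytotoxicity, read by MTT assay; on this read-out lower numbers stand for higher toxicity in this test and higher numbers for lower toxicity in this test:
- compound 1 `O=c1cc(Cc2c(F)cccc2F)nc(Sc2ccccc2)[nH]1`: > 76000 nM
- compound 2 `O=c1cc(Cc2c(F)cccc2F)nc(SCc2ccccc2)[nH]1`: > 73000 nM
- compound 3 `O=c1cc(Cc2c(F)cccc2F)nc(SCCc2ccccc2)[nH]1`: > 70000 nM

Each of these three values is a limit of this assay and not a measured number. For compound 1 the limit is the limit of > 76000 nM in this assay, at which 1 of the 3 values shown sits. For compound 2 it is the limit of > 73000 nM in this assay, at which 1 of the 3 values shown sits. For compound 3 it is the limit of > 70000 nM in this assay, at which 1 of the 3 values shown sits. Compound 3 therefore stands at a limit, and the two other values shown are limits as well, so it cannot be placed above or below them.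

The steps among the measured compounds are a step that the two limits leave unreadable from compound 1 to compound 2, a step that the two limits leave unreadable from compound 1 to compound 3 and a step that the two limits leave unreadable from compound 2 to compound 3; none of them can be read, since each end is a limit.

Compound 4 `CC(=O)CSc1nc(Cc2c(F)cccc2F)cc(=O)[nH]1` arises from compound 3 by the change (acetyl in place of benzyl on a saturated chain carbon bound to a sulfur). On the same place, the earlier swaps of phenyl, benzyl and phenethyl gave no readable step, so the bearing of this change on this assay cannot be sized from what is shown, and no step beyond the scatter is expected in either direction.

For compound 4 the expected value in this assay is 70000 nM, within 20000 nM to 200000 nM, most likely again reported as a limit. The step this estimate means is a number no higher from compound 3 to compound 4 (the limit leaves the size open).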

Compound 4, half-maximal cytotoxic concentration: > 81000 nM
Compound 4: no number, only a limit; the forecaster's own chance of this, stated with the estimate: 85%; middle value at least 1.1-fold (0.06 log units) from the limit.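

In this assay compound 4 gives > 81000 nM, which is a limit and not a measured number. Its steps to compound 1, compound 2 and compound 3 cannot be read, as both ends of each are limits. The compounds shown leave open at what concentration any of these four harms the cells, and whether changing the group on the sulfur shifts that concentration at all.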